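The source may report more compounds than this note shows. Statements on the series, on what has been measured and on what is new or still open speak of the compounds shown alone.

Compound 1 `O=C(O)CN1CCC2(CCC(C(=O)N3CCN(c4ccncc4)CC3)CC2)CC1` serves as the point of reference in this set. In a functional assay with Homo sapiens as the target (a lower number here means a stronger inhibitor, a higher number a weaker inhibitor), compound 1 gives 117 nM. Compound 2 `O=C(O)CCN1CCC2(CCC(C(=O)N3CCN(c4ccncc4)CC3)CC2)CC1` differs from it in one place: carboxymethyl in place of carboxy on a saturated chain carbon bound to an amine nitrogen in a ring In this assay compound 2 gives 7900 nM, and the step of a 68-fold higher number from compound 1 to compound 2 (1.83 log units; beyond the scatter) is the only measured step of this kind among these compounds. Compound 3 `O=C(O)CC(=O)N1CCC2(CCC(C(=O)N3CCC(C4CCNCC4)CC3)CC2)CC1` rests on a different core; how its core differs from the core of compound 1 is not broken down here. In this assay compound 3 gives 2500 nM, a number that stands between the other two measured values. For the measured compounds named here, compound 4 `O=C(O)CCC(=O)N1CCC2(CCC(C(=O)N3CCC(C4CCNCC4)CC3)CC2)CC1` has not been measured; it differs from compound 3 in one place: carboxymethyl in place of carboxy on a saturated chain carbon bound to a carbonyl carbon This is the same kind of change as the one from compound 1 to compound 2, but the place is not the same: in the earlier pair the change sits on a saturated chain carbon bound to an amine nitrogen in a ring, while here it sits on a saturated chain carbon bound to a carbonyl carbon. With a different core and a different place, the earlier step is only a rough guide. Compound 4 is therefore expected to be the weaker inhibitor, by an estimated step of a 6.0-fold higher number from compound 3 to compound 4 (0.78 log units; beyond the scatter), because the step of a 68-fold higher number from compound 1 to compound 2 (1.83 log units; beyond the scatter) was large, while the different place leaves room for a smaller effect. For compound 4 the expected value is 15000 nM, with a likely range from 3000 nM to 80000 nM.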

Compound 4, half-maximal inhibitory concentration: 50000 nM
Beside the measured number, compound 4's estimate is 3.3-fold (0.52 log units) below it, and the stated range covers the measured number.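

In this assay the new pair gives a 20-fold higher number from compound 3 to compound 4 (1.30 log units; beyond the scatter) and so forms a large step in the same direction as the step seen on the core of compound 1. The change from carboxy to carboxymethyl thus raised the number on both cores, but the size of the step did not carry over from one to the other: the same change on two cores in this assay, a 68-fold higher number (1.83 log units; beyond the scatter) from compound 1 to compound 2 and a 20-fold higher number (1.30 log units; beyond the scatter) from compound 3 to compound 4, 3.4-fold (0.53 log units) apart, beyond the scatter of two such steps. The two pairs differ both in the core and in the place of the change, a saturated chain carbon bound to an amine nitrogen in a ring in one and a saturated chain carbon bound to a carbonyl carbon in the other, so they do not show which of the two sets the size of the step, and two pairs give no rule for any further core.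

The compounds shown leave open whether a longer chain than 2-carboxyethyl, ending in the same carboxylic acid, would raise the number further, and whether a primary amide in place of the carboxylic acid would keep the same trend. They also leave open how the two places would compare on one and the same core, the comparison that would separate the place of the change from the core itself.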